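The source may hold more compounds than are shown below. What is called first, only, known or untested is meant among the compounds shown, and "the series" means these compounds.

Working notes on the sulfonyl variations of the shared core.

Compound 3 `CN(C)S(=O)(=O)NC(=O)c1ccc(Nc2nc(NC3(c4ccc(Cl)cc4)CC3)nc(OCC(F)(F)F)n2)cc1` carries a dimethylamino group on the sulfonyl sulfur. In an ADME assay on microsomes from liver (Rattus norvegicus) for metabolic stability, with a stated time of 10 min (a higher number here means that more of the compound is left, a lower number that less of the compound is left), compound 3 gives 76%. Compound 2 `CS(=O)(=O)NC(=O)c1ccc(Nc2nc(NC3(c4ccc(Cl)cc4)CC3)nc(OCC(F)(F)F)n2)cc1` has a methyl there, and in this assay compound 2 gives 85%; the step of a number 9 percentage points lower from compound 2 to compound 3 (within the scatter) sits within the scatter, so the two are not separated. Compound 1 `CC(C)NCCS(=O)(=O)NC(=O)c1ccc(Nc2nc(NC3(c4ccc(Cl)cc4)CC3)nc(OCC(F)(F)F)n2)cc1` carries a 2-(isopropylamino)ethyl group, and in this assay compound 1 gives 100%; the steps of a number 15 percentage points lower from compound 1 to compound 2 (beyond the scatter) and a number 24 percentage points lower from compound 1 to compound 3 (beyond the scatter) both lie beyond the scatter, so compound 3 stands clearly below compound 1 and level with compound 2.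

Compound 4 `NCCS(=O)(=O)NC(=O)c1ccc(Nc2nc(NC3(c4ccc(Cl)cc4)CC3)nc(OCC(F)(F)F)n2)cc1` is next, with the change (2-aminoethyl in place of dimethylamino on a sulfonyl sulfur). This partly reverses the step from compound 1 to compound 3, since a basic chain returns to the sulfonyl sulfur, though without the isopropyl group. The step of a number 24 percentage points lower from compound 1 to compound 3 (beyond the scatter) is the one that bears on it; the step of a number 9 percentage points lower from compound 2 to compound 3 (within the scatter) shows that a swap between small nonbasic groups does little. A modest rise is therefore expected, towards but not necessarily reaching compound 1, giving an expected step of a number 14 percentage points higher from compound 3 to compound 4 (beyond the scatter). For compound 4 in this assay the estimate is 90%, with a range from 72% to 100%.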

Compound 4, percent of the compound remaining: 100%
Beside the measured number, compound 4's estimate is 10 percentage points below it; low and high end bracket the measured number.
By their numbers in this assay, from the lowest: compounds 3 and 2 (each within the scatter of the next); then compounds 1 and 4 (each within the scatter of the next).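

In this assay, the 2-aminoethyl group on the sulfonyl sulfur lifts the compound clear of both small groups, with a number 24 percentage points higher from compound 3 to compound 4 (beyond the scatter) and a number 15 percentage points higher from compound 2 to compound 4 (beyond the scatter), so among these four compounds the two carrying an aminoethyl chain stand above the two carrying methyl or dimethylamino, with no compound going against this. The isopropyl group on the amine nitrogen proves unnecessary for this level, as hydrogen in its place gives no change at the digits printed from compound 1 to compound 4 (within the scatter) and the two compounds are not separated. Nothing at hand gives a reason for these steps.

Going by these compounds, whether the rise belongs to the amine or to the two-carbon chain itself stays open, and a 2-hydroxyethyl or plain ethyl group on the sulfonyl sulfur would separate the two. A longer chain such as 3-aminopropyl, or a tertiary amine such as 2-(dimethylamino)ethyl, would show how far the chain and the amine nitrogen can change while compound 4 keeps its 100% in this assay.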